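Drawing One Stereocentre: From Compound 1 to Compound 3

This account rests on a few compounds, and the source may have more. Where it says the series, first, only, none or still open, it means among the compounds named here.

Compound 1, `OCC(O)COc1nc(N2CCCCC2)c2nc(OCC(O)CO)nc(N3CCCCC3)c2n1`: 83%
Compound 2, `CCCOc1nc(N2CCCCC2)c2nc(OCCC)nc(N3CCCCC3)c2n1`: 60%

Of the compounds shown here, two have been measured in a functional assay on L1210 cells (Mus musculus) for inhibition, read by thymidine incorporation, tested at 100 uM; on this read-out lower numbers stand for a weaker effect and higher numbers for a stronger effect at the one concentration tested. Compound 1 gives 83% and stands highest of the two numbers; compound 2 gives 60%, a result that lies beyond the scatter below that of compound 1.

The piece follows the step from compound 1 to the not yet measured compound 3, `OCC(O)COc1nc(N2CCCCC2)c2nc(OC[C@H](O)CO)nc(N3CCCCC3)c2n1`. The change is as follows: the two compounds have the same atoms and bonds; at least one stereo element is drawn with a configuration in one of them and without one in the other: 1 of 2 stereo elements differ; a stereocentre at a saturated chain carbon is drawn without a configuration in compound 1 and R in compound 3. Compound 3 therefore keeps every atom and bond of compound 1, and the only distinction is that one of its two stereocentres is drawn with an R configuration where compound 1 shows none.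

Within the data shown here, no measured pair of this kind is available, so the size of the step in this assay can only be expected. Such a change is expected to move the number little, if at all, and not beyond the scatter in either direction.

Compound 3 is estimated to give 82%, within 68% to 94%. The expected step of a number 1 percentage points lower from compound 1 to compound 3 (within the scatter) is thus estimated to be small.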

Compound 3, a percentage reported as inhibition, at one concentration (the size of the read-out at that concentration, not a potency): 87%
Compound 3: middle estimate off by 5 percentage points, on the low side; measured number inside the range.
By their numbers in this assay, from the lowest: compound 2; then compounds 1 and 3 (each within the scatter of the next).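

In this assay, among these compounds, this is the first measured step of its kind at this position, a number 4 percentage points higher from compound 1 to compound 3 (within the scatter). Drawing the stereocentre at a saturated chain carbon as R therefore leaves the read-out within the scatter, something compounds 1 and 2 could not show because they formed no pair differing in one place. The comparison rests on a single distinction, and it shows no measurable consequence at the one concentration tested: the fact that one of compounds 1 and 3 is drawn with a defined configuration and the other without, at the place where they differ

The compounds shown leave open how the S configuration at this stereocentre, or a defined configuration at the second stereocentre, would read in this assay. They also leave open whether an amine or a carboxylic acid in place of a hydroxyl group on these chains would keep the number where compound 3 stands.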